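Removing the methoxy group of compound 1

This account rests on a few compounds, and the source may have more. Where it says the series, first, only, none or still open, it means among the compounds named here.

compound 1 `COc1ccc(C(F)(F)F)cc1Nc1ncc(C(F)(F)F)c(N2Cc3cccc(N(C)S(C)(=O)=O)c3C2)n1`: > 30000 nM
compound 2 `COc1cc(Nc2ncc(C(F)(F)F)c(N3Cc4cccc(N(C)S(C)(=O)=O)c4C3)n2)cc(OC)c1`: > 30000 nM
compound 3 `Cc1ccc(Nc2ncc(C(F)(F)F)c(N3Cc4cccc(N(C)S(C)(=O)=O)c4C3)n2)c(C)c1`: > 30000 nM

Of the compounds shown here, three sharing the core of compound 1 have been tested in a functional assay on U-87MG ATCC cells for antiproliferative activity against U-87 MG (Homo sapiens), read by spectrophotometry, with a stated time of 2 days; on this read-out lower numbers stand for stronger inhibition of growth and higher numbers for weaker inhibition of growth. Compound 1 gives only the limit of the assay, > 30000 nM. Compound 2 likewise returns the limit > 30000 nM. Compound 3 also sits at the limit, > 30000 nM. Because all three values stand at the same limit (the limit of > 30000 nM in this assay, at which 3 of the 3 values shown sit), none of the steps between them can be read: the step that the two limits leave unreadable from compound 1 to compound 2, the step that the two limits leave unreadable from compound 1 to compound 3 and the step that the two limits leave unreadable from compound 2 to compound 3 are each of unknown size. Compound 1 therefore stands at the limit, indistinguishable on these numbers from the other two.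

Compound 4 `CN(c1cccc2c1CN(c1nc(Nc3cccc(C(F)(F)F)c3)ncc1C(F)(F)F)C2)S(C)(=O)=O` differs from compound 1 by hydrogen in place of methoxy on an aromatic carbon. The three measured steps each swap the whole aryl group on the nitrogen; none isolates a methoxy group alone, and every one of them is unreadable, so they only show that three different aryl groups all left the value at the limit. The expected step is a number no higher from compound 1 to compound 4 (the limit leaves the size open), within the scatter, with a high chance that only a limit is reported again. Compound 4 is accordingly estimated at 30000 nM, with a range from 8000 nM to 100000 nM.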

Compound 4, concentration for 50% growth inhibition: > 30000 nM
Compound 4 ended at the assay's limit; the forecaster's own chance of this, stated with the estimate: 80%; the middle value lies on the limit itself.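

In this assay compound 4 also gives only a limit, > 30000 nM. No step from compound 1, compound 2 or compound 3 to compound 4 can be read, because every value stands at the same limit: the limit of > 30000 nM in this assay, at which 4 of the 4 values shown sit.

The compounds shown leave open whether hydrogen in place of methoxy, or any of the aryl swaps, changes growth inhibition at all.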